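What a mirror image might do to cell potency

A few compounds are considered here, and "the series" means these few. Any claim that something is new, unique, unknown or untested is made for them only; others in the source may bear on it.

Compound 1 `CC1=NN(c2ccccc2)C(=O)[C@@]12C(=O)C=CC[C@@H]2c1ccccc1[N+](=O)[O-]` gives 68300 nM in this set
Compound 2 `CC1=NN(c2ccccc2)C(=O)[C@@]12C(=O)C=CC[C@@H]2c1cccc(C)c1` gives 6800 nM in this set
Compound 3 `COc1ccccc1[C@@H]1CC=CC(=O)[C@]12C(=O)N(c1ccccc1)N=C2C` gives 5140 nM in this set

All three numbers come from a functional assay on MDA-MB-231 cells (Homo sapiens) for inhibition, read by MTT assay, with a stated time of 72 h (a higher number here means a weaker inhibitor, a lower number a stronger inhibitor), and compound 3 at 5140 nM lies within the scatter of compound 2 at 6800 nM and well under compound 1. Compound 4 `COc1ccccc1[C@H]1CC=CC(=O)[C@@]12C(=O)N(c1ccccc1)N=C2C` has the same atoms and bonds as compound 3, and the difference, the two compounds have the same atoms and bonds and differ only in configuration as drawn: 2 of 2 stereo elements differ (all stereocentres are inverted: mirror images); a stereocentre at a saturated ring carbon is drawn S in compound 3 and R in compound 4; a stereocentre at a saturated ring carbon is drawn S in compound 3 and R in compound 4 and nothing else, makes the two mirror images. For the measured compounds named here, the one measured step, a 10-fold lower number from compound 1 to compound 2 (1.00 log units; beyond the scatter) on exchanging a group, shows that numbers in this set can move far, but it says nothing direct about mirror images. Going by the values given here, no such pair has been measured, so the data give no firm direction. A shift of a 1.4-fold higher number from compound 3 to compound 4 (0.13 log units; within the scatter) is what is expected here, an estimated move that stays inside the scatter. For compound 4 the estimate in this assay is 7000 nM as the middle, with an expected range from 2500 nM up to 25000 nM to allow for that gap.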

Compound 4, half-maximal inhibitory concentration: 15700 nM
For compound 4 the middle estimate is 2.2-fold (0.35 log units) below the measured one; the range from low to high includes it.
By their numbers in this assay, from the lowest: compounds 3 and 2 (each within the scatter of the next); then compound 4; then compound 1.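

In this assay, for the compounds shown here, inverting both stereocentres is enough to move the number, a 3.1-fold higher number from compound 3 to compound 4 (0.48 log units; beyond the scatter), something no earlier step could show, since the only earlier step exchanged a group. The gap can be put down to configuration alone, because nothing else separates the pair: the fact that compounds 3 and 4 differ only in the configuration as drawn. The mirror image also changes how group exchanges read: compound 3 lies within the scatter of compound 2, yet there is a 2.3-fold higher number from compound 2 to compound 4 (0.36 log units; beyond the scatter) with 2-methoxyphenyl in place of 3-methylphenyl, and a 4.4-fold lower number from compound 1 to compound 4 (0.64 log units; beyond the scatter) with methoxy in place of nitro.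

On these data alone, whether the mirror images of compound 1 and compound 2 would separate by a similar amount stays open. So does whether an amine or a carboxylic acid in place of the methoxy would keep this gap between mirror images.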